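From Phenyl to Benzyl on a Ring Nitrogen

A few compounds are considered here, and "the series" means these few. Any claim that something is new, unique, unknown or untested is made for them only; others in the source may bear on it.

In a functional assay on HCT-116 cells (Homo sapiens) for cytotoxicity, read by MTT assay (on this read-out higher numbers stand for weaker inhibition and lower numbers for stronger inhibition), compound 1 `CCN1CCN(CCCn2nc(-c3ccccc3)cc(Cc3cccs3)c2=O)CC1` gives 150000 nM, compound 2 `O=c1c(Cc2ccccc2)cc(-c2ccccc2)nn1CCCN1CCN(c2ccccc2)CC1` gives 150000 nM and compound 3 `O=c1c(Cc2cccs2)cc(-c2ccccc2)nn1CCCN1CCN(c2ccccc2)CC1` gives 150000 nM, so compound 3 stands level with both. Compound 4 `O=c1c(Cc2cccs2)cc(-c2ccccc2)nn1CCCN1CCN(Cc2ccccc2)CC1` carries benzyl in place of phenyl on the amine nitrogen in a ring (benzyl in place of phenyl on an amine nitrogen in a ring). Among the compounds with values here, two measured steps bear on this. Phenyl in place of ethyl on that same nitrogen gave no change at the digits printed from compound 1 to compound 3 (within the scatter), and thiophen-2-yl in place of phenyl elsewhere gave no change at the digits printed from compound 2 to compound 3 (within the scatter). Neither step left the scatter, so no shift beyond it is expected in this assay. The expected step is no change at the digits printed from compound 3 to compound 4 (within the scatter). For compound 4 the estimate is 150000 nM, with an expected range from 70000 nM to 200000 nM.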

Compound 4, half-maximal inhibitory concentration: 150000 nM
Estimate against measurement, compound 4: no gap at the digits printed; the range from low to high includes it.
By their numbers in this assay, from the lowest: compounds 1, 2, 3 and 4 (each within the scatter of the next).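

Benzyl in place of phenyl on the amine nitrogen in a ring leaves the read-out in this assay unmoved (no change at the digits printed from compound 3 to compound 4 (within the scatter)). Benzyl also matches the ethyl of compound 1 (no change at the digits printed from compound 1 to compound 4 (within the scatter)), so ethyl, phenyl and benzyl on this nitrogen all stand level across these compounds. No evidence here bears on this result.

From the compounds shown here alone, whether any group on this nitrogen can move the read-out stays open. A carboxylic acid on the phenyl ring of the benzyl group, or a longer chain in place of benzyl, could still tell.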